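The source may hold more compounds than are shown below. What is called first, only, known or untested is meant among the compounds shown, and "the series" means these compounds.

In a functional assay on HGC-27 cells (Homo sapiens) for inhibition, read by MTT assay, with a stated time of 72 h (a lower number here means a stronger inhibitor, a higher number a weaker inhibitor), compound 1, `Cc1cc(N2CC[C@@H](C)[C@@H](N(C)c3ncnc4[nH]ccc34)C2)n2nc(SCc3nc4ccccc4[nH]3)nc2n1`, gives > 100000 nM, which is a limit and not a number. Compound 2, `Cc1nc2nc(SCc3ccc(Cl)cc3)nn2c(N2CC[C@@H](C)[C@@H](N(C)c3ncnc4[nH]ccc34)C2)c1C`, gives > 100000 nM, again a limit and not a number. Compound 3, `Cc1cc(N2CC[C@@H](C)[C@@H](N(C)c3ncnc4[nH]ccc34)C2)n2nc(SCC3CCCCC3)nc2n1`, is the only one of the three with a true number, 11500 nM.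

The next structure is compound 4, `CCCSc1nc2nc(C)cc(N3CC[C@@H](C)[C@@H](N(C)c4ncnc5[nH]ccc45)C3)n2n1`, which has ethyl in place of cyclohexyl on a saturated chain carbon bound to a sulfur. The same difference can also be read as cyclohexylmethyl to propyl. Among the compounds with values here, no measured step makes this exact exchange, and no compound with ethyl at this place has a result yet.

The closest guide is an at least 8.6-fold lower number from compound 1 to compound 3 (0.93 log units; beyond the scatter), where cyclohexyl stands in place of 1H-benzimidazol-2-yl at the same place. That step shows that the group here can shift the number, and that compound 1, the one without cyclohexyl, lies on the higher side at > 100000 nM. Removing the cyclohexyl ring from compound 3 is therefore expected to raise the number modestly in this assay, though the evidence for this is thin. The expected change is a 2.6-fold higher number from compound 3 to compound 4 (0.42 log units; beyond the scatter). For compound 4, the estimate is 30000 nM, with an expected range from 9000 nM to 100000 nM.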

Compound 4, half-maximal inhibitory concentration: 20900 nM
Compound 4: middle estimate off by 1.4-fold (0.16 log units), on the high side; the measured number falls inside the stated range.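

In this assay, replacing the cyclohexyl group with ethyl on the saturated chain carbon bound to a sulfur gives a 1.8-fold higher number from compound 3 to compound 4 (0.26 log units; within the scatter), so cyclohexylmethyl and propyl cannot be told apart in this assay. Within the data shown here, the earlier compounds could not show this: until now, the only true number belonged to a compound with a six-membered carbon ring at this place, and this result shows that such a ring is not needed for a measurable number. The open chain also differs clearly from the 1H-benzimidazol-2-yl group at the same place, with an at least 4.7-fold lower number from compound 1 to compound 4 (0.67 log units; beyond the scatter), so two quite different saturated carbon groups, one ring and one chain, now stand apart from that group.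

From the compounds shown here alone, the true size of this last step stays unknown because one end of it is a limit and not a number: the limit of > 100000 nM in this assay, at which 2 of the 4 values shown sit. Also open is whether a methyl group, a longer chain such as hexyl, or a chain ending in an amine or a carboxylic acid would move the number beyond the scatter in this assay, in either direction, from where the propyl and cyclohexylmethyl compounds sit.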